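The source may report more compounds than this note shows. Statements on the series, on what has been measured and on what is new or still open speak of the compounds shown alone.

Compound 3 `Cc1ccccc1NC(=O)NC1CC(C)(C)Oc2ccc(Cl)cc21` is the reference point of this series. In a functional assay (aorta) with Rattus norvegicus as the target (a lower number here means that less compound is needed, a higher number that more compound is needed for the effect), compound 3 gives only a limit, > 10000 nM. Two neighbours differ from it in one place. Compound 1 `COc1ccccc1NC(=O)NC1CC(C)(C)Oc2ccc(Cl)cc21` carries methoxy where compound 3 carries methyl; in this assay compound 1 likewise reaches only a limit, > 10000 nM. Compound 2 `Cc1ccccc1NC(=O)NC1CC(C)(C)Oc2ccc(F)cc21` carries fluoro where compound 3 carries chloro; in this assay compound 2 gives a limit, > 30000 nM. Within the data shown here, the step that the two limits leave unreadable from compound 1 to compound 3 and the step that the two limits leave unreadable from compound 2 to compound 3 therefore cannot be sized; the only evidence is the limit of > 10000 nM in this assay, at which 2 of the 3 values shown sit, and (the limit of > 30000 nM in this assay, at which 1 of the 3 values shown sits). Compound 4 `CC1(C)CC(NC(=O)Nc2cccc(Cl)c2)c2cc(Cl)ccc2O1` differs from compound 3 by 3-chlorophenyl in place of 2-methylphenyl on an amide-type nitrogen. Among the measured compounds shown here, no measured step bears on this change, and none of the three values shows a compound with a readable number in this assay. Compound 4 is therefore expected to remain weak, the step that the limit leaves unreadable from compound 3 to compound 4 being an estimate without precedent in the series. Compound 4 is estimated at 15000 nM, within 3000 nM to 60000 nM, pending its measurement.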

Compound 4, half-maximal effective concentration: > 30000 nM
Compound 4: a limit, no number; the forecaster's own chance of this, stated with the estimate: 60%; at least 2.0-fold (0.30 log units) between middle value and limit.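

In this assay, among these compounds, compound 1, compound 3 and compound 4 give only limits, so no step to compound 4 can be read. The compounds shown leave open what effect 3-chlorophenyl in place of 2-methylphenyl has, and whether any change on the shared core gives a readable number.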